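Compound 3 to compound 4: chloro becomes fluoro

A few compounds are considered here, and "the series" means these few. Any claim that something is new, unique, unknown or untested is made for them only; others in the source may bear on it.

In an ADME assay on HEK-293T cells (Homo sapiens) for inhibition, read by CCK-8 assay, with a stated time of 48 h, tested at 20 uM (a higher number here means more inhibition of growth at the concentration tested, a lower number less inhibition of growth), compound 1 `COc1ccc(S(=O)(=O)Oc2ccccc2/C=C(\C#N)C(=O)Nc2nnc(Cc3cccc4ccccc34)s2)cc1` gives 29%, and compound 3 `N#C/C(=C\c1ccccc1OS(=O)(=O)c1ccc(Cl)cc1)C(=O)Nc1nnc(Cc2cccc3ccccc23)s1` gives 16%. Compound 2 `N#C/C(=C\c1ccccc1OS(=O)(=O)c1ccccc1[N+](=O)[O-])C(=O)Nc1nnc(Cc2cccc3ccccc23)s1` is recorded only as "not toxic" (no number reported), without a number. Compound 3 therefore holds the lower of the two numbers available.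

Compound 4 `N#C/C(=C\c1ccccc1OS(=O)(=O)c1ccc(F)cc1)C(=O)Nc1nnc(Cc2cccc3ccccc23)s1` differs from compound 3 by a single swap, fluoro in place of chloro on an aromatic carbon, para to a large group, which turns 4-chlorophenyl into 4-fluorophenyl.

Going by the values given here, only one measured step bears on this swap: a number 13 percentage points lower from compound 1 to compound 3 (beyond the scatter), where chloro took the place of methoxy. It is a modest step, and it involves a different pair of groups, so it is only a loose guide. Among the compounds with values here, no measured pair compares chloro with fluoro directly. In this assay the expected change is small, with no clear direction and nothing beyond the usual scatter, and the estimated step is a number 1 percentage points lower from compound 3 to compound 4 (within the scatter). For compound 4 the estimate is 15%, with an expected range from 4% to 28%.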

Compound 4, percent growth inhibition at one concentration: 15%
For compound 4 middle estimate and measured number coincide at the digits printed; the range from low to high includes it.
By their numbers in this assay, from the lowest: compounds 4 and 3 (each within the scatter of the next); then compound 1.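

In this assay, the 4-chlorophenyl and 4-fluorophenyl compounds cannot be told apart, so exchanging one of these halogens for the other on this aromatic carbon has no readable effect (a number 1 percentage points lower from compound 3 to compound 4 (within the scatter)). Methoxy now stands apart from two halogens rather than one, since fluoro in its place also gives a lower number, beyond the scatter (a number 14 percentage points lower from compound 1 to compound 4 (beyond the scatter)), as chloro did. Nothing available explains why the two halogens match or why methoxy differs from them.

Going by these compounds, it remains open how groups of other kinds at this position, such as an amine, a carboxylic acid or a longer alkyl chain, would compare with these three. Compound 2 is recorded only as "not toxic", so its steps to the other compounds cannot be read.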